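Cytotoxicity notes on compounds 1 to 4 of the series

The source may report more compounds than this note shows. Statements on the series, on what has been measured and on what is new or still open speak of the compounds shown alone.

Measured so far:
Compound 1 `CN1C(=S)[C@@H](NC(=O)c2nc(Cc3ccccc3)n(C)n2)COc2ccccc21` in a toxicity assay on HT-29 cells (Homo sapiens) for cytotoxicity (on this read-out lower numbers stand for higher toxicity in this test and higher numbers for lower toxicity in this test), gives > 100000 nM, which is a limit of the assay rather than a number.
Compound 2 `CCCCn1nc(C(=O)N[C@H]2COc3ccccc3N(C)C2=S)nc1Cc1ccccc1` in this assay gives > 100000 nM, again a limit of the assay.
Compound 3 `CC(C)Cn1nc(C(=O)N[C@H]2COc3ccccc3N(C)C2=S)nc1Cc1ccccc1` in this assay gives > 100000 nM, again a limit of the assay.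

Compound 3 therefore stands at the limit, and the two further values shown are limits as well (the limit of > 100000 nM in this assay, at which 3 of the 3 values shown sit). The three steps among the measured compounds, a step that the two limits leave unreadable from compound 1 to compound 2, a step that the two limits leave unreadable from compound 1 to compound 3 and a step that the two limits leave unreadable from compound 2 to compound 3, cannot be read in size because both ends of each sit at the limit (the limit of > 100000 nM in this assay, at which 3 of the 3 values shown sit).

Compound 4 `CN1C(=S)[C@@H](NC(=O)c2nc(Cc3ccccc3)n(-c3ncccn3)n2)COc2ccccc21` differs from compound 3 by pyrimidin-2-yl in place of isobutyl on an aromatic nitrogen. The measured steps all vary the group on the same aromatic nitrogen and so bear on this position, but none of them gives a readable size or direction. On that basis no step beyond the scatter is expected in this assay; the step the estimate below implies, a number no higher from compound 3 to compound 4 (the limit leaves the size open), is expected to be small. Compound 4 is thus expected to give 100000 nM, with a range from 30000 nM to 300000 nM, and most likely another limit.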

Compound 4, half-maximal cytotoxic concentration: > 100000 nM
Compound 4: no number, only a limit (the forecaster's own chance of this, stated with the estimate: 70%); the middle value lies on the limit itself.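

The steps from compound 1, compound 2 and compound 3 to compound 4 cannot be read in size, because both ends of each sit at the limit: the limit of > 100000 nM in this assay, at which 4 of the 4 values shown sit.

The compounds shown leave open whether any group on this aromatic nitrogen shifts the read-out in this assay, and what number any of the four would give.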